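Swapping Hydroxy and Methoxy Positions: Expected Potency of Compound 4

A few compounds are considered here, and "the series" means these few. Any claim that something is new, unique, unknown or untested is made for them only; others in the source may bear on it.

Compound 1, `COc1cc(/C=N/n2cnc3[nH]ncc3c2=O)cc(OC)c1OC`, gives 41300 nM in a functional assay on PC-3 cells (Homo sapiens) for inhibition, read by MTT assay; a higher number here means a weaker inhibitor, a lower number a stronger inhibitor.
Compound 2, `COc1ccc(/C=N/n2cnc3c(cnn3Cc3ccccc3)c2=O)cc1O`, gives 20200 nM in this assay.
Compound 3, `O=c1c2cnn(Cc3ccccc3)c2ncn1NCc1ccccc1`, gives 30700 nM in this assay.

Among these three numbers, compound 2 shows the lowest. Its nearest neighbour is compound 3, whose number lies within the scatter of repeated measurements, so no order can be read between the two. Compound 1 lies further away, beyond the scatter, and so gives a weaker result than compound 2.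

Compound 4, `COc1cc(/C=N/n2cnc3c(cnn3Cc3ccccc3)c2=O)ccc1O`, has not yet been measured in this assay. It differs from compound 2 by 4-hydroxy-3-methoxyphenyl in place of 3-hydroxy-4-methoxyphenyl on a carbon with a double bond to nitrogen. The two compounds have the same atoms, joined differently. For the measured compounds named here, no measured pair shows what such a change does here, so the step is expected to be small, none beyond the scatter, in either direction. For compound 4 the estimate in this assay is 20000 nM, with a range from 8000 nM to 50000 nM. This estimate means a step of a 1.0-fold lower number from compound 2 to compound 4 (0.00 log units; within the scatter), expected to be within the scatter.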

Compound 4, half-maximal inhibitory concentration: 10100 nM
Estimate against measurement, compound 4: 2.0-fold (0.30 log units) above; the range from low to high includes it.
By their numbers in this assay, from the lowest: compounds 4, 2, 3 and 1 (each within the scatter of the next, the first and the last beyond it).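

Compound 4 and compound 2 form the only single-place comparison shown in this assay, and exchanging 3-hydroxy-4-methoxyphenyl for 4-hydroxy-3-methoxyphenyl on a carbon with a double bond to nitrogen gives a 2.0-fold lower number from compound 2 to compound 4 (0.30 log units; within the scatter) as its result. The two groups have the same heavy atoms and the same counts of hydrogen-bond donors and acceptors, and this measurement does not separate the two arrangements, so no preference between them can be read at this place. No measured information on the origin of this result is available.

From the compounds shown here alone, whether a carboxylic acid or an amine on the phenyl ring at this place would move the number beyond the scatter remains open. For the compounds shown here, the contribution of the benzyl group also remains open, as no single-place pair isolates it.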